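From ethyl to (morpholin-4-yl)carbonyl: little change expected

A few compounds are considered here, and "the series" means these few. Any claim that something is new, unique, unknown or untested is made for them only; others in the source may bear on it.

Compound 1 `COc1ncc(-c2ccc3nc(NC(=O)NCC(=O)N4CCCCC4)nn3c2)cc1NS(=O)(=O)c1ccc(F)cc1` gives 740 nM in a functional assay on U-87MG ATCC cells for cytotoxicity against U-87 MG (Homo sapiens), read by MTT assay, with a stated time of 72 h (on this read-out lower numbers stand for stronger inhibition and higher numbers for weaker inhibition), and compound 2 `CCCNC(=O)Nc1nc2ccc(-c3cnc(OC)c(NS(=O)(=O)c4ccc(F)cc4)c3)cn2n1` gives 420 nM in the same test. Within the data shown here, the one measured step between them is a 1.8-fold lower number from compound 1 to compound 2 (0.25 log units; within the scatter) and so these two values cannot be told apart. Among the measured compounds shown here, compound 2 therefore stands together with compound 1 on the numbers so far.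

Compound 3 `COc1ncc(-c2ccc3nc(NC(=O)NCC(=O)N4CCOCC4)nn3c2)cc1NS(=O)(=O)c1ccc(F)cc1` has not yet been measured. It differs from compound 2 by (morpholin-4-yl)carbonyl in place of ethyl on a saturated chain carbon bound to an amide-type nitrogen and this is the change followed here.

The closest evidence is the step already measured at that same place, where compound 1 carries (piperidin-1-yl)carbonyl. Read backwards, it shows what a similar exchange did, and it stayed within the scatter. For the measured compounds named here, no morpholine-bearing compound has been measured, so the forecast rests on this single pair, and no step beyond the scatter is expected in this assay here. The estimate amounts to an expected 1.5-fold higher number from compound 2 to compound 3 (0.19 log units; within the scatter) in this test. Compound 3 is expected to give 650 nM (estimated range 250 nM to 1700 nM).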

Compound 3, half-maximal inhibitory concentration: 3260 nM
Beside the measured number, compound 3's estimate is 5.0-fold (0.70 log units) below it, outside the stated range (above it).
By their numbers in this assay, from the lowest: compounds 2 and 1 (each within the scatter of the next); then compound 3.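

In this assay, the place on the saturated chain carbon bound to an amide-type nitrogen turns out not to be indifferent to what it carries: morpholin-4-yl in place of piperidin-1-yl on the carbonyl carbon gives a 4.4-fold higher number from compound 1 to compound 3 (0.64 log units; beyond the scatter), although the two rings differ only by an oxygen where piperidine has a carbon. The comparison with the simpler chain points the same way, with (morpholin-4-yl)carbonyl in place of ethyl giving a 7.8-fold higher number from compound 2 to compound 3 (0.89 log units; beyond the scatter), so a ring-bearing carbonyl group is not in itself what weakens the result, since compound 1 also carries one and stays within the scatter of compound 2. Nothing available here accounts for the weaker result of the morpholine, and the numbers record only that it occurs.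

From the compounds shown here alone, whether the ring oxygen itself matters, or whether any other atom at that ring position would act alike, remains open, and a piperazine, with a ring nitrogen, or a thiomorpholine, with a ring sulfur, would help to separate these cases. Also open, going by these compounds, is whether an open-chain dimethylamide at this place would behave like the piperidine or like the morpholine.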